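The source may report more compounds than this note shows. Statements on the series, on what has been measured and on what is new or still open speak of the compounds shown alone.

Measured so far in a functional assay on the whole organism (Tail, strain ICR) with Mus musculus as the target, in the tail flick test, with a stated time of 60 min, at a dose of 25 umol/kg by the oral route; a higher number here means a stronger effect of the compound at the dose given, a lower number a weaker effect:
- compound 1 `O=C(CN(c1nc(Cl)nc2[nH]cnc12)C1CC1)NCC(=O)OCc1ccccc1`: 41.9%
- compound 2 `O=C(CN(c1ncnc2c1ncn2C1CCCCO1)C1CC1)NCC(=O)OCc1ccccc1`: 40.4%
- compound 3 `CC[C@H](C)[C@H](NC(=O)CN(c1nc(Cl)nc2[nH]cnc12)C1CC1)C(=O)O`: 36%

Compound 1 holds the highest of the three numbers shown, yet both compound 2 and compound 3 sit within the usual scatter of it, so the three cannot be ranked. Among the measured compounds shown here, no pair of measured compounds differs in one place, and no step is available to guide the next one. Compound 4 `O=C(CN(c1nc(Cl)nc2[nH]cnc12)C1CC1)N[C@@H](CC(=O)OCc1ccccc1)C(=O)OCc1ccccc1` differs from compound 1 by (benzyloxycarbonyl)methyl in place of hydrogen on a saturated chain carbon bound to an amide-type nitrogen and a carbonyl carbon. With compound 3, which carries a different side chain at the same position, giving 36%, the expectation for this assay is a step of no size beyond the scatter, in no set direction, as a number 2.9 percentage points lower from compound 1 to compound 4 (within the scatter) expresses. Compound 4 is therefore estimated at 39%, in the range 26% to 52%.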

Compound 4, a percentage reported as activity, at one dose (the size of the read-out at that dose, not a potency): 22.4%
Compound 4: middle estimate off by 16.6 percentage points, on the high side; measured number below the stated range.
By their numbers in this assay, from the lowest: compound 4; then compounds 3, 2 and 1 (each within the scatter of the next).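

In this assay, (benzyloxycarbonyl)methyl in place of hydrogen on a saturated chain carbon bound to an amide-type nitrogen and a carbonyl carbon comes with a number 19.5 percentage points lower from compound 1 to compound 4 (beyond the scatter). Among the compounds shown here, this is the first step that can be read, and it shows that a change at this position can lower the read-out at the dose given. Nothing at hand accounts for the loss.

From the compounds shown here alone, it stays open whether the loss follows from the whole (benzyloxycarbonyl)methyl group or from only part of it. A plain methyl or a carboxymethyl group at the same carbon would separate these two readings.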